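Compound 2 to compound 4: replacing the acylazetidine group

The compounds below may be only part of what the source reports. "The series", "measured", "known", "first", "only" and "open" are said of these compounds alone.

In a physicochemical assay for solubility, measured as kinetic solubility (on this read-out lower numbers stand for lower solubility and higher numbers for higher solubility), compound 1 `COc1ccc(S(=O)(=O)Nc2ccc(CN3C[C@@H]4C[C@H]3CN4C(=O)c3cccc(Cl)c3)cc2)cc1` gives 47000 nM. Compound 3 `COc1ccc(S(=O)(=O)Nc2ccc(OC3CCN(C(=O)c4cccc(Cl)c4)CC3)cc2)cc1` gives < 1000 nM, which is a limit and not a number. Compound 2 `COc1ccc(S(=O)(=O)Nc2ccc(CN3CCN(C(=O)C4CN(C(C)=O)C4)CC3)cc2)cc1` gives >= 511000 nM, also a limit and not a number, so its standing is known only as a limit. Compound 4 `COc1ccc(S(=O)(=O)Nc2ccc(CN3CCN(C(=O)Cn4cccnc4=O)CC3)cc2)cc1` differs from compound 2 at one place, on a carbonyl carbon: a group of 8 heavy atoms (5 carbon, 2 nitrogen, 1 oxygen; one six-membered aromatic ring with 2 hetero atoms) in place of a group of 7 heavy atoms (5 carbon, 1 nitrogen, 1 oxygen; one four-membered non-aromatic ring with 1 hetero atom), on a carbonyl carbon. Among the compounds with values here, no measured pair shows this change. The expected step of an at least 1.7-fold lower number from compound 2 to compound 4 (0.23 log units; that floor lies within the scatter) is a modest fall in this assay, possibly no larger than the scatter. This expectation rests on the limit of compound 2, >= 511000 nM. For compound 4 the estimated value is 300000 nM, with an expected range of 100000 nM to 550000 nM.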

Compound 4, solubility: >= 336000 nM
Compound 4: a limit, no number; the forecaster's own chance of this, stated with the estimate: 35%; middle value at least 1.1-fold (0.04 log units) from the limit.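

In this assay, within the data shown here, compound 2 and compound 4 both read as limits and not as numbers, so no step between them can be read. The compounds shown leave open which of the two reads higher, and by how much.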